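The compounds below may be only part of what the source reports. "The series", "measured", "known", "first", "only" and "open" are said of these compounds alone.

Three compounds share one core and differ only in the group attached to an aromatic nitrogen of the five-membered ring. For compound 1 `Brc1ccc(-n2cc(COc3ccc4c(c3)CCC4)nn2)cc1` the result in an ADME assay on HEK293 cells (Homo sapiens) for inhibition, read by MTT assay, with a stated time of 48 h, tested at 25 uM (a higher number here means more inhibition at the concentration tested (going by the name of the read-out), a lower number less inhibition), is given as "not determined" (no result reported), so it offers no number. Compound 2 `Cc1ccc(-n2cc(COc3ccc4c(c3)CCC4)nn2)c(C)c1` gives 19.9% in this assay. Compound 3 `Cc1cccc(-n2cc(COc3ccc4c(c3)CCC4)nn2)c1` gives 23.4% in this assay. Among the compounds with values here, of the two numbers, that of compound 3 sits at the top, yet the only measured step, a number 3.5 percentage points higher from compound 2 to compound 3 (within the scatter), is within the scatter, so the two compounds are not told apart by this read-out. The next compound, compound 4 `Brc1ccccc1-n1cc(COc2ccc3c(c2)CCC3)nn1`, differs from compound 3 by 2-bromophenyl in place of 3-methylphenyl on an aromatic nitrogen. Within the data shown here, the single measured step exchanged a 2,4-dimethylphenyl for a 3-methylphenyl and moved the number by less than the scatter; no measured step brings a bromine onto this phenyl, and compound 1 offers no number. On this footing no movement beyond the scatter is expected in this assay, and the expected step is a number 1.4 percentage points lower from compound 3 to compound 4 (within the scatter). Compound 4 is therefore estimated at 22%, within 5% to 40%.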

Compound 4, a percentage reported as inhibition, at one concentration (the size of the read-out at that concentration, not a potency): 16.5%
Beside the measured number, compound 4's estimate is 5.5 percentage points above it; measured number inside the range.
By their numbers in this assay, from the lowest: compounds 4, 2 and 3 (each within the scatter of the next).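

In this assay, putting 2-bromophenyl on the aromatic nitrogen gives a number 6.9 percentage points lower from compound 3 to compound 4 (within the scatter) and, set against the 2,4-dimethylphenyl group, a number 3.4 percentage points lower from compound 2 to compound 4 (within the scatter). Within the data shown here, this is the first measured case of a bromine on this phenyl, and it shows that trading methyl groups for a bromine here does not separate compound 4 from either neighbour in this read-out, so all three measured compounds remain indistinguishable. Nothing available explains these numbers.

Still open, going by these compounds, is whether a phenyl carrying an amine or a carboxylic acid, or a longer chain in place of the phenyl, would move the number beyond the scatter. On these data alone, whether the place of the bromine on the phenyl matters is also open, as compound 1 gives "not determined" (no result reported).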